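Swapping a Methoxy for a Dimethylamino on a Shared Core

The source may report more compounds than this note shows. Statements on the series, on what has been measured and on what is new or still open speak of the compounds shown alone.

Of the compounds shown here, two built on one core have been tested in a functional assay on the whole organism (strain Wistar) for inhibition, with Rattus norvegicus as the target, read by paw edema, with stated times of 1 h and 5 h, at a dose of 20 mg/kg by the oral route; on this read-out lower numbers stand for less inhibition and higher numbers for more inhibition at the one dose given (going by the name of the read-out). Compound 1 `NS(=O)(=O)c1ccc2nc(N3N=C(c4ccc(Br)cc4)CC3c3ccc(F)cc3)sc2c1` gives 14%. Compound 2 `COc1ccc(C2CC(c3ccc(Br)cc3)=NN2c2nc3ccc(S(N)(=O)=O)cc3s2)cc1` gives 14%, so compound 2 stands level with compound 1, and the change no change at the digits printed from compound 1 to compound 2 (within the scatter) is within the scatter.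

Compound 3 `CN(C)c1ccc(C2CC(c3ccc(Br)cc3)=NN2c2nc3ccc(S(N)(=O)=O)cc3s2)cc1` is not yet measured. It differs from compound 2 in one place: dimethylamino in place of methoxy on an aromatic carbon. Among the measured compounds shown here, the only step measured so far, from fluoro to methoxy, changed nothing beyond the scatter in this assay, and it touched the same position on the same ring. For the measured compounds named here, that single step is the only guide here, and it points to no shift. For compound 3 the expected step of no change at the digits printed from compound 2 to compound 3 (within the scatter) is therefore small, without a direction that can be told from the data. The estimate for compound 3 is 14%, with a range from 4% to 28%.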

Compound 3, a percentage reported as inhibition, in the whole organism at one dose (the size of the read-out at that dose, not a potency): 14%
The estimate for compound 3 equals the measured number at the digits printed; low and high end bracket the measured number.
By their numbers in this assay, from the lowest: compounds 1, 2 and 3 (each within the scatter of the next).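

In this assay, putting dimethylamino in place of methoxy gives no change at the digits printed from compound 2 to compound 3 (within the scatter), so a group with one more heavy atom, and with nitrogen in place of oxygen, leaves the read-out where it was. Setting the two ends of the series side by side, dimethylamino in place of fluoro gives no change at the digits printed from compound 1 to compound 3 (within the scatter), which means that across these three compounds this position, para to a large group, has taken three different groups with no difference beyond the scatter at this one dose. No measurement at hand explains why the read-out stays level.

Going by these compounds, whether a carboxylic acid or a longer chain such as butoxy at this position would move the read-out remains open. So does the effect of a change anywhere else on the shared core.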